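Ester to Sulfone on a Shared Amide Core

This account rests on a few compounds, and the source may have more. Where it says the series, first, only, none or still open, it means among the compounds named here.

Of the compounds shown here, three built on one shared core have been tested in an ADME assay on PC-3 cells (Homo sapiens) for cytotoxicity, read by WST assay, tested at 100 uM; a lower number here means less inhibition, a higher number more inhibition at the concentration tested (going by the name of the read-out). Compound 1 `CSc1cccc(NC(=O)C2CCCN(C(=O)c3cc(C(F)(F)F)cc(C(F)(F)F)c3)C2)c1` gives 0%. Compound 2 `COC(=O)c1cccc(C(=O)N2CCCC(C(=O)Nc3ccc(Cl)cc3)C2)c1` gives 0%, equal to compound 1 and within the scatter of compound 3. Compound 3 `O=C(Nc1cccc(OCCc2ccccn2)c1)C1CCCN(C(=O)c2cc(C(F)(F)F)cc(C(F)(F)F)c2)C1` gives 5%. The single one-place step among these three, a number 5 percentage points higher from compound 1 to compound 3 (within the scatter), lies within the scatter, so none of them shows a clear effect on the cells at the concentration tested.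

Compound 4 `CS(=O)(=O)c1cccc(C(=O)N2CCCC(C(=O)Nc3ccc(Cl)cc3)C2)c1` has not yet been measured. It differs from compound 2 in one place: methylsulfonyl in place of methoxycarbonyl on an aromatic carbon. Among the compounds with values here, no measured step changes this group, so there is no direct guide for it. Within the data shown here, what the data do show is that all three measured compounds sit near zero, and the one measured change, from compound 1 to compound 3, did not move the number beyond the scatter. A step beyond the scatter is therefore not expected for compound 4, and its number is expected to stay close to that of compound 2, meaning a number 2 percentage points higher from compound 2 to compound 4 (within the scatter). The estimate for compound 4 is 2%, with an expected range from 0% to 12%.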

Compound 4, a percentage reported as inhibition, at one concentration (the size of the read-out at that concentration, not a potency): 2%
Compound 4: the middle estimate sits on the measured number at the digits printed; low and high end bracket the measured number.
By their numbers in this assay, from the lowest: compounds 1, 2, 4 and 3 (each within the scatter of the next).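

In this assay, within the data shown here, the new result gives the first measured step at this position, an aromatic carbon meta to a large group: with methylsulfonyl in place of methoxycarbonyl, there is a number 2 percentage points higher from compound 2 to compound 4 (within the scatter). The two groups have the same number of heavy atoms and hydrogen-bond acceptors, neither has a hydrogen-bond donor, a ring or a net charge, and they differ in that sulfur replaces one carbon and in their double bonds outside aromatic rings, yet this read-out cannot tell the two compounds apart. No separate measurement is available to explain why these two groups read alike.

On these data alone, whether a carboxylic acid, an amine or a longer chain on this same aromatic carbon would give a number beyond the scatter of compound 2 remains open. Also open, as far as these compounds go, is whether the same exchange would read alike on a compound carrying the 3,5-bis(trifluoromethyl)benzoyl group of compound 1, since this single pair shows the change only with the rest of compound 2 around it.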